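Amino to nitro in the hydroxycyclohexyl series

This account rests on a few compounds, and the source may have more. Where it says the series, first, only, none or still open, it means among the compounds named here.

Measured in an ADME assay on cells (Hepatocyte, Mus musculus) for metabolic stability, with a stated time of 30 min; on this read-out lower numbers stand for a less stable compound and higher numbers for a more stable compound:
- compound 1 `Cc1ccc(C(=O)OC2CCC(CN3CCN(c4cc(=O)c5cc(C(F)(F)F)cc([N+](=O)[O-])c5s4)CC3)CC2)cc1`: 18%
- compound 2 `Nc1cc(C(F)(F)F)cc2c(=O)cc(N3CCN(CC4CCC(O)CC4)CC3)sc12`: 60%

Of these two numbers, compound 2 holds the higher at 60%, and the gap down to compound 1 lies beyond the scatter. Two compounds give only a thin basis for any trend.

Next in line is compound 3 `O=c1cc(N2CCN(CC3CCC(O)CC3)CC2)sc2c([N+](=O)[O-])cc(C(F)(F)F)cc12`, not yet measured in this assay. It departs from compound 2 by a single change, nitro in place of amino on an aromatic carbon.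

For the measured compounds named here, no measured pair isolates this change, so its effect has not been seen directly. Going by the values given here, the one measured compound carrying nitro, compound 1, gives 18%, but it also differs from compound 2 elsewhere. A downward step in this assay is therefore expected, probably beyond the scatter, though smaller than the whole gap between the two measured compounds. The expected step is a number 18 percentage points lower from compound 2 to compound 3 (beyond the scatter). Compound 3 is estimated at 42%, with an expected range of 20% to 68%.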

Compound 3, percent of the compound remaining: 51.2%
Estimate against measurement, compound 3: 9.2 percentage points below; measured number inside the range.
By their numbers in this assay, from the lowest: compound 1; then compounds 3 and 2 (each within the scatter of the next).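

In this assay, nitro in place of amino on an aromatic carbon, at the place ortho to a fused ring and meta to a trifluoromethyl group, gives a number 8.8 percentage points lower from compound 2 to compound 3 (within the scatter), so on this read-out the two groups are not separated when the hydroxycyclohexyl oxygen carries hydrogen. The larger difference lies at the other end of the molecule: hydrogen in place of (4-methylphenyl)carbonyl on an oxygen on a saturated carbon gives a number 33.2 percentage points higher from compound 1 to compound 3 (beyond the scatter), which ties the low value of compound 1 to that acyl group and not to the nitro group it shares with compound 3. The data at hand offer no independent measurement that would account for either step.

It remains open whether amino and nitro also stay within the scatter of each other when the (4-methylphenyl)carbonyl group is present on the oxygen, since the amino partner of compound 1 is not among the compounds shown. Also open, going by these compounds, is how a nitrile, a carboxylic acid or plain hydrogen at the aromatic position would read in this assay, and whether a smaller acyl group such as acetyl on the oxygen would give a step of similar size.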